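The source may report more compounds than this note shows. Statements on the series, on what has been measured and on what is new or still open speak of the compounds shown alone.

Three compounds share a core and were measured in a functional assay on Hep 3B2 cells (Homo sapiens) for antiproliferative activity, read by MTT assay, with a stated time of 24 h, tested at 0.05 ug/mL; a lower number here means a weaker effect, a higher number a stronger effect of the compound at the concentration tested. Compound 1, with the structure `Cc1c(C(=O)Nc2c(F)cc(-c3cccc(F)c3)cc2F)nc2ccc(F)cc2c1O`, gives 1.25%. Compound 2, with the structure `CCOc1ccc2nc(C(=O)Nc3c(F)cc(-c4cccc(F)c4)cc3F)c(C)c(O)c2c1`, carries ethoxy in place of fluoro on an aromatic carbon and gives -0.04%. The step from compound 1 to compound 2 amounts to a number 1.3 percentage points lower from compound 1 to compound 2 (within the scatter), which is within the usual scatter of repeated measurements. Compound 3, with the structure `Cc1c(C(=O)Nc2c(F)cc(-c3cccc(F)c3)cc2F)nc2ccc(F)cc2c1C(=O)O`, gives 0.05%; it differs from compound 1 by carboxy in place of hydroxy on an aromatic carbon, and the step is a number 1.2 percentage points lower from compound 1 to compound 3 (within the scatter), again within the scatter. Taken together, the three measured compounds all sit close to zero inhibition at the tested concentration, and no one of them can be called stronger or weaker than another.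

Compound 4, with the structure `CCOc1ccc2nc(C(=O)Nc3c(F)cc(-c4cccc(F)c4)cc3F)c(C)c(C(=O)O)c2c1`, has not yet been measured. It differs from compound 3 by ethoxy in place of fluoro on an aromatic carbon, the same change as the one from compound 1 to compound 2, made at the same place and on a core that differs only as described above. Because that earlier change produced a number 1.3 percentage points lower from compound 1 to compound 2 (within the scatter), the step from compound 3 to compound 4 in this assay is expected to be similarly small, about a number 0.1 percentage points lower from compound 3 to compound 4 (within the scatter). On this basis compound 4 is estimated to give 0%, with a likely range from -10% to 10%.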

Compound 4, a percentage reported as inhibition, at one concentration (the size of the read-out at that concentration, not a potency): 0.98%
Compound 4: the middle estimate sits 1 percentage points below what was measured, within the range that was stated.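

In this assay, ethoxy in place of fluoro on the core of compound 3 gives a number 0.9 percentage points higher from compound 3 to compound 4 (within the scatter), and this change reads alike on the two cores: the same change on two cores in this assay, a number 1.3 percentage points lower (within the scatter) from compound 1 to compound 2 and a number 0.9 percentage points higher (within the scatter) from compound 3 to compound 4, 2.2 percentage points apart, within the scatter of two such steps. Carboxy in place of hydroxy on the core of compound 2 gives a number 1 percentage points higher from compound 2 to compound 4 (within the scatter), and this change also reads alike on its two cores: the same change on two cores in this assay, a number 1.2 percentage points lower (within the scatter) from compound 1 to compound 3 and a number 1 percentage points higher (within the scatter) from compound 2 to compound 4, 2.2 percentage points apart, within the scatter of two such steps. Neither change therefore shows a detectable dependence on the core, but this does not prove that either one carries over reliably: all four compounds stay close to zero inhibition at this single concentration, so the comparison only sets small steps within the scatter beside one another, and it says nothing about how these changes would behave on a compound with a clear effect.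

As far as these compounds go, it remains open whether an amine or a longer chain in place of the ethoxy, or an amide in place of the carboxy, would lift the reading clearly away from zero. From the compounds shown here alone, it also remains open how these four compounds would compare at a higher concentration, where a real difference between them might become readable.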